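Swapping the pyridine acyl group on a trifluoromethyl anilide

The source may report more compounds than this note shows. Statements on the series, on what has been measured and on what is new or still open speak of the compounds shown alone.

Measured compounds:
- compound 1, `O=C(Nc1cc(C(F)(F)F)ccc1N1CCCCC1)c1cccnc1Cl`: "not active" (no number reported) in a functional assay on NALM-6 cells (Homo sapiens) for cytotoxicity, read by MTT assay, with a stated time of 48 h; on this read-out lower numbers stand for stronger inhibition and higher numbers for weaker inhibition
- compound 2, `CCN(CC)c1ccc(C(F)(F)F)cc1NC(=O)c1ccncc1`: 63600 nM in this assay

Among the measured compounds shown here, compound 2 is the only compound of the pair with a numerical result. In this assay compound 2 gives 63600 nM, a weak effect. Compound 1 is recorded as "not active" (no number reported) in this assay, with no number to set beside it.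

Compound 3, `CCN(CC)c1ccc(C(F)(F)F)cc1NC(=O)c1cccnc1Cl`, is not yet measured. It differs from compound 2 in one place: 2-chloropyridin-3-yl in place of pyridin-4-yl on a carbonyl carbon. The amide nitrogen, the trifluoromethyl group and the diethylamino group of compound 2 are kept unchanged.

For the measured compounds named here, no step between two measured compounds describes this change, so its size cannot be read from the data. The starting point is already weak, and the only other entry gave no number at all. Compound 3 is therefore expected to stay weak, and a modest step from compound 2 to compound 3 of a 1.3-fold higher number from compound 2 to compound 3 (0.10 log units; within the scatter) in this assay is estimated, with the possibility that only a limit is reported. For compound 3 an estimate of 80000 nM is given, within a range of 20000 nM to 300000 nM.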

Compound 3, half-maximal inhibitory concentration: "not active" (no number reported)
No number was reported for compound 3; the estimate stays without a comparison.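

In this assay, among the compounds shown here, compound 3 is recorded as "not active" (no number reported) and compound 2 gives 63600 nM as its number, so no step between compound 2 and compound 3 can be read. On these data alone, whether any acyl group on the shared core gives more than a weak effect in this assay stays open. Nothing shown explains the result of compound 3.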